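A few compounds are considered here, and "the series" means these few. Any claim that something is new, unique, unknown or untested is made for them only; others in the source may bear on it.

Working notes on the series. Compound 3 `Oc1ccc(-c2cc(-c3ccccc3)nc(-c3cccc(Cl)c3)c2)cc1` was tested in an ADME assay on HEK293 cells (Homo sapiens) for cytotoxicity, read by CCK-8 assay and cell counting, with a stated time of 2 days (a higher number here means a weaker inhibitor, a lower number a stronger inhibitor), and gives 2820 nM. Compound 2 `Oc1cccc(-c2cc(-c3ccsc3)nc(-c3cccc(Cl)c3)c2)c1` gives 3180 nM in this assay, and the two numbers lie within the scatter of each other, so no order between compound 2 and compound 3 can be read. Compound 1 `Oc1cccc(-c2cc(-c3cccc(Cl)c3)nc(-c3ccccn3)c2)c1` gives "not determined" (no result reported) in this assay, so no number is available for it. Compound 4 `Oc1cccc(-c2cc(-c3ccccc3)nc(-c3cccc(Cl)c3)c2)c1` differs from compound 3 by 3-hydroxyphenyl in place of 4-hydroxyphenyl on an aromatic carbon. For the measured compounds named here, no measured pair shows this change on its own, and compound 2 already carries the 3-hydroxyphenyl group at a similar number, so the expectation is a step from compound 3 to compound 4 of a 1.1-fold higher number from compound 3 to compound 4 (0.03 log units; within the scatter), nothing beyond the scatter. Compound 4 is accordingly expected at 3000 nM, within a range of 1200 nM to 8000 nM.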

Compound 4, half-maximal inhibitory concentration: 3120 nM
Beside the measured number, compound 4's estimate is 1.0-fold (0.02 log units) below it, and the stated range covers the measured number.
By their numbers in this assay, from the lowest: compounds 3, 4 and 2 (each within the scatter of the next).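

In this assay, for the compounds shown here, 3-hydroxyphenyl in place of 4-hydroxyphenyl, at the position opposite the ring nitrogen, gives a 1.1-fold higher number from compound 3 to compound 4 (0.04 log units; within the scatter), the first direct reading of this change on its own. Phenyl in place of thiophen-3-yl on an aromatic carbon gives a 1.0-fold lower number from compound 2 to compound 4 (0.01 log units; within the scatter), so both single changes stay within the scatter.

On these data alone, whether a carboxylic acid or an amine in place of the hydroxyl on this ring would shift the number beyond the scatter remains open. Nothing available points to a cause for either step.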